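The compounds below may be only part of what the source reports. "The series", "measured", "known", "first", "only" and "open" are said of these compounds alone.

Measured so far:
compound 1, `COC(=O)c1sc2cc(OC)ccc2c1C#Cc1ccccc1F` — 7200 nM in a functional assay on NCI-H460 cells (Homo sapiens) for cytotoxicity, read by sulforhodamine B assay, with a stated time of 48 h; a higher number here means a weaker inhibitor of growth, a lower number a stronger inhibitor of growth
compound 2, `COC(=O)c1sc2ccccc2c1C#Cc1ccc(OC)cc1` — > 150000 nM

For the measured compounds named here, compound 1 is the only member of the pair with a numbered value, giving 7200 nM in this assay. Compound 2 reaches no number: this assay reports only a limit for compound 2, > 150000 nM. The limit is described as the limit of > 150000 nM in this assay, at which 1 of the 2 values shown sits. Going by the values given here, compound 1 and compound 2 differ in more than one place, so their two values show only that compound 1 sits at a number while compound 2 does not.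

The next compound, compound 3 with structure `COC(=O)c1sc2ccccc2c1C#Cc1ccc(F)cc1`, is not yet measured in this assay. It is derived from compound 2 by the change (fluoro in place of methoxy on an aromatic carbon). Among the compounds with values here, no step between measured compounds stands with a number, so no size for this kind of change is known here. Given that compound 2 sits at a limit, the step in this assay can hardly run weaker; the expectation is a move toward a stronger value, with a real chance that compound 3 also stays at the limit. Compound 3 is therefore estimated at 60000 nM, with a range from 8000 nM to 150000 nM. This estimate for compound 3 means an expected step of an at least 2.5-fold lower number from compound 2 to compound 3 (0.39 log units; beyond the scatter).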

Compound 3, concentration for 50% growth inhibition: 76100 nM
Compound 3: middle estimate off by 1.3-fold (0.10 log units), on the low side; measured number inside the range.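

In this assay, with fluoro in place of methoxy on an aromatic carbon para to a large group, compound 3 reads as a number, 76100 nM. For the compounds shown here, compound 2 stands at a limit and not at a number, so the size of this change can be given only as a floor, because the true position of compound 2 is unknown: the limit of > 150000 nM in this assay, at which 1 of the 3 values shown sits. The pair provides the only single-place step, an at least 1.9-fold lower number from compound 2 to compound 3 (0.29 log units; that floor lies within the scatter), so the floor alone does not establish a real difference between methoxy and fluoro at this position, although the true step may be larger.

Compound 1, at 7200 nM, differs from compound 3 in more than one place, so it cannot show how far changes at this position alone could carry the series in this assay. From the compounds shown here alone, how a chloro, a hydroxyl or an amine at this same place would read remains open, as does whether the step would hold with a carboxylic acid in place of the methyl ester.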